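The source may report more compounds than this note shows. Statements on the series, on what has been measured and on what is new or still open speak of the compounds shown alone.

In an ADME assay on WI-38 VA13 cells (Homo sapiens) for cytotoxicity, read by MTT assay, with a stated time of 72 h (a higher number here means that more compound is tolerated, a lower number that less compound is tolerated), compound 1 (`[N-]=[N+]=NCCCCCC(=O)N(CCCC[C@H](NC(=O)N[C@@H](CCC(=O)O)C(=O)O)C(=O)O)Cc1ccc(Cl)cc1`) gives > 100000 nM as its reading, which is a limit of the assay and not a number. Compound 2 (`[N-]=[N+]=NCCCCCC(=O)N(CCCC[C@H](NC(=O)N[C@@H](CCC(=O)O)C(=O)O)C(=O)O)Cc1ccc(Br)cc1`) has no place on that scale: its entry reads "not determined" (no result reported) with no number behind it. The next compound is compound 3 (`[N-]=[N+]=NCCCCCC(=O)N(CCCC[C@H](NC(=O)N[C@@H](CCC(=O)O)C(=O)O)C(=O)O)Cc1ccc(O)cc1`). The change is hydroxy in place of bromo on an aromatic carbon and puts hydroxy in place of bromo on an aromatic carbon, para to a large group, while the rest of the molecule stays the same. Among the compounds with values here, no measured pair shows what this swap does here. Within the data shown here, the only reading to go on is the limit of compound 1 at > 100000 nM and from it no step beyond the usual scatter is expected in this assay for this change. For compound 3 the estimated half-maximal cytotoxic concentration is 100000 nM (range 40000 nM to 150000 nM).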

Compound 3, half-maximal cytotoxic concentration: 50200 nM
Compound 3: middle estimate off by 2.0-fold (0.30 log units), on the high side; measured number inside the range.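

In this assay compound 3 gives 50200 nM as a true number, the first one at this place on the aromatic ring. Compound 1 reads > 100000 nM and that is a limit of the assay and not a number. Hydroxy in place of chloro gives an at least 1.9-fold lower number from compound 1 to compound 3 (0.29 log units; that floor lies within the scatter) and this floor alone does not separate the two compounds, so the change is not shown to make a real difference to how well these cells tolerate the compound.

How large the step really is stays open because one end of it is a limit: the limit of > 100000 nM in this assay, at which 1 of the 3 values shown sits.

Going by these compounds, the step from bromo to hydroxy cannot be read since compound 2 has no result, and what an amine, a carboxylic acid or a longer chain at this place would do in this assay remains unknown.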